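Phenyl replacement on the core of compound 1

A few compounds are considered here, and "the series" means these few. Any claim that something is new, unique, unknown or untested is made for them only; others in the source may bear on it.

Values in an ADME assay (liver) for metabolic stability, with Liver microsome (Homo sapiens) as the target, read by LC-MS, using microsomes, with a stated time of 1 h, tested at 5 uM (on this read-out higher numbers stand for a more stable compound and lower numbers for a less stable compound), so far:
compound 1 `Cc1nc(-c2ccccc2)c(C(=O)N2CCN(c3cccc(Cl)c3)CC2)o1` gives 13.5%
compound 2 `Cc1nc(-c2ccccc2)c(C(=O)N2CCN(c3cccc(C)c3C)CC2)o1` gives 29.8%

Compound 1 holds the lower of these two numbers. Among the measured compounds shown here, the only measured step is a number 16.3 percentage points higher from compound 1 to compound 2 (beyond the scatter) and lies beyond the scatter. It is a modest step, with 2,3-dimethylphenyl in place of 3-chlorophenyl on an amine nitrogen in a ring.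

Compound 3 `COc1cc(-c2nc(C)oc2C(=O)N2CCN(c3cccc(Cl)c3)CC2)ccc1O` differs from compound 1 elsewhere, with 4-hydroxy-3-methoxyphenyl in place of phenyl on an aromatic carbon on an aromatic carbon of the five-membered aromatic ring. The measured step sits at another place, so it does not bear directly on this change. It shows only the size that one change has reached in this assay here. For the measured compounds named here, no compound with a change at this place has been measured, so the data give no direction, and no step beyond the scatter is expected. The expected change is a number 1.5 percentage points lower from compound 1 to compound 3 (within the scatter) in this estimate. Compound 3 is estimated at 12% with an expected range from 4% to 28% for this measurement.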

Compound 3, percent of the compound remaining: 70.3%
Beside the measured number, compound 3's estimate is 58.3 percentage points below it; measured number outside the range, above it.
By their numbers in this assay, from the lowest: compound 1; then compound 2; then compound 3.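

In this assay, the aromatic carbon of the five-membered aromatic ring, next to the ring nitrogen, turns out to be a place that responds strongly: 4-hydroxy-3-methoxyphenyl in place of phenyl gives a number 56.8 percentage points higher from compound 1 to compound 3 (beyond the scatter) as a large step. Among the compounds shown here, the earlier pair kept the phenyl fixed and showed only a number 16.3 percentage points higher from compound 1 to compound 2 (beyond the scatter) as a modest step on an amine nitrogen in a ring, so the larger response so far lies at the phenyl position and not at the group changed there. The entering group brings a hydrogen-bond donor and hydrogen-bond acceptors that the phenyl lacks, but no measurement at hand tells what in this change accounts for the rise.

The compounds shown leave open whether the hydroxy group or the methoxy group carries the step, as a 4-hydroxyphenyl or a 3-methoxyphenyl at this place would separate the two. They also leave open whether the rise holds with 2,3-dimethylphenyl on the amine nitrogen, and whether a pyridine ring or a phenyl bearing a carboxylic acid behaves in the same way here.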